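This account rests on a few compounds, and the source may have more. Where it says the series, first, only, none or still open, it means among the compounds named here.

Measured in a functional assay on cells (Mast cell, Rattus norvegicus) for inhibition, with a stated time of 15 min; on this read-out lower numbers stand for an effect already at smaller amounts and higher numbers for an effect only at larger amounts of compound:
compound 1 `N#Cc1ccc2oc(C(=O)Nc3nnn[nH]3)cc(=O)c2c1`: 2.3 ug/mL
compound 2 `Cc1ccc2oc(C(=O)Nc3nnn[nH]3)cc(=O)c2c1`: 0.075 ug/mL

Of these two numbers, the lower belongs to compound 2, and compound 1 is its nearest neighbour. The next structure, compound 3 `O=C(Nc1nnn[nH]1)c1cc(=O)c2cc(Cl)ccc2o1`, differs from compound 2 by chloro in place of methyl on an aromatic carbon, with chloro in place of methyl on an aromatic carbon. Within the data shown here, only one measured step touches that carbon: a 31-fold lower number from compound 1 to compound 2 (1.49 log units; beyond the scatter), a large change beyond the scatter when methyl replaced cyano. Among the measured compounds shown here, it shows that the number in this assay can move strongly with the group at this place, but no chloro compound has been measured, so its size does not transfer directly. A moderate rise in the number is expected, ending between the two measured compounds and nearer compound 2. The expected change is a 2.7-fold higher number from compound 2 to compound 3 (0.43 log units; beyond the scatter). For compound 3 the estimated value is 0.2 ug/mL, with an expected range of 0.04 ug/mL to 1 ug/mL.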

Compound 3, concentration for half-maximal effect: 0.75 ug/mL
Compound 3: the middle estimate sits 3.8-fold (0.57 log units) below what was measured; the range from low to high includes it.
By their numbers in this assay, from the lowest: compound 2; then compound 3; then compound 1.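

In this assay, the exchange of methyl for chloro on this aromatic carbon gives a 10-fold higher number from compound 2 to compound 3 (1.00 log units; beyond the scatter), so the number moves beyond the scatter even without the cyano group. Chloro in place of cyano gives a 3.1-fold lower number from compound 1 to compound 3 (0.49 log units; beyond the scatter), placing compound 3 in the middle of this three-member set, with methyl giving the lowest number and cyano the highest. No available evidence accounts for this order.

These three compounds do not show whether another group at this carbon, such as fluoro, methoxy, ethyl or an amine, would give a number lower than that of compound 2. From the compounds shown here alone, whether the same order would hold with a carboxylic acid or a longer chain at this carbon also remains open.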